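The source may hold more compounds than are shown below. What is called first, only, known or untested is meant among the compounds shown, and "the series" means these compounds.

Measured in a physicochemical assay for lipophilicity (on this read-out higher numbers stand for higher lipophilicity and lower numbers for lower lipophilicity), for three compounds
compound 1 `CCCCCCN(CCCCCSc1nc2ccccc2s1)C(=O)Nc1ccc(F)cc1F` gives 7.78
compound 2 `CCCCCCCN(CCCCCSc1nc(N)c2c[nH]nc2n1)C(=O)Nc1ccc(F)cc1F` gives 5.74
compound 3 `CCCCCCCN(CCCCCSc1nc(N)c2c[nH]nc2n1)C(=O)NC(C)C` gives 5.14

Compound 2 stands second of these three, above compound 3 and well under compound 1. Compound 4 `CCCCCCCN(CCCCCSc1n[nH]c(-c2ccccc2)n1)C(=O)Nc1ccc(F)cc1F` comes next, with this change from compound 2 (a group of 11 heavy atoms (8 carbon, 3 nitrogen; one five-membered aromatic ring with 3 hetero atoms, one six-membered aromatic ring of carbon only) in place of a group of 10 heavy atoms (5 carbon, 5 nitrogen; one five-membered aromatic ring with 2 hetero atoms, one six-membered aromatic ring with 2 hetero atoms), on a sulfur). Among the compounds with values here, the one measured step (a number 0.60 log units lower from compound 2 to compound 3 (beyond the scatter)) is modest and sits on an amide-type nitrogen, so no measured step covers a change on the sulfur. With compound 1 (7.78) as the only higher reference, a rise beyond the scatter is expected in this assay for this change. The expected change (a number 1.56 log units higher from compound 2 to compound 4 (beyond the scatter)) is upward and sizeable. Expected for compound 4: 7.3 (estimated range 6.5 to 8).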

Compound 4, partition coefficient: 6.78
Compound 4: the middle estimate sits 0.52 log units above what was measured, and the stated range covers the measured number.
By their numbers in this assay, from the lowest: compound 3; then compound 2; then compound 4; then compound 1.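

In this assay, the group on the sulfur carries a large step of its own: a number 1.04 log units higher from compound 2 to compound 4 (beyond the scatter), with 5-phenyl-1H-1,2,4-triazol-3-yl entering. Within the data shown here, the only earlier step lay on an amide-type nitrogen, a number 0.60 log units lower from compound 2 to compound 3 (beyond the scatter), so this position adds a step in the opposite direction. Nothing measured here explains the change at this position.

Both rings change at once, so the share of the phenyl ring and that of the triazole ring stay apart from reach. Also open, as far as these compounds go, is how a carboxylic acid or an amine on that phenyl ring would read, and whether the step holds with isopropyl on the amide-type nitrogen.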